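From benzyl to 2-sulfamoylethyl on the shared core

This account rests on a few compounds, and the source may have more. Where it says the series, first, only, none or still open, it means among the compounds named here.

In a functional assay on the whole organism with Rattus norvegicus as the target (on this read-out lower numbers stand for an effect already at smaller amounts and higher numbers for an effect only at larger amounts of compound), compound 1 `CCCCn1c(=N)sc2cc(OC(F)(F)F)ccc21` gives 10 mg/kg and compound 2 `C=CCn1c(=N)sc2cc(OC(F)(F)F)ccc21` gives 7 mg/kg on the same read-out. Compound 3 `N=c1sc2cc(OC(F)(F)F)ccc2n1Cc1ccccc1` gives > 10 mg/kg as a limit and not a number. Compound 4 `N=c1sc2cc(OC(F)(F)F)ccc2n1CCS(N)(=O)=O` differs from compound 3 in one place: sulfamoylmethyl in place of phenyl on a saturated chain carbon bound to an aromatic nitrogen.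

Of the measured steps at this place, a 1.4-fold lower number from compound 1 to compound 2 (0.15 log units; within the scatter) stays within the scatter, a number no lower from compound 1 to compound 3 (the limit leaves the size open) has its size left open by the limit, and an at least 1.4-fold higher number from compound 2 to compound 3 (0.15 log units; that floor lies within the scatter) has a floor within the scatter. None of them brings in sulfamoylmethyl, so no direction can be read from them. Going by the values given here, with compound 2 at 7 mg/kg and compound 1 at 10 mg/kg as the only numbers here, compound 4 is expected near them. The expected change in this assay is a number no higher from compound 3 to compound 4 (the limit leaves the size open) and no step beyond the scatter is expected. For compound 4 the estimate is 10 mg/kg with 3 mg/kg to 30 mg/kg as the expected range.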

Compound 4, dose for half-maximal effect: 6 mg/kg
Beside the measured number, compound 4's estimate is 1.7-fold (0.22 log units) above it; measured number inside the range.
By their numbers in this assay, from the lowest: compounds 4, 2 and 1 (each within the scatter of the next).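

In this assay, going by these compounds alone, the place on a saturated chain carbon bound to an aromatic nitrogen takes sulfamoylmethyl, with a hydrogen-bond donor and acceptors, and compound 4 still gives a number, whereas the groups on the earlier compounds held carbon only. Against the carbon chains the steps are a 1.2-fold lower number from compound 2 to compound 4 (0.07 log units; within the scatter) and a 1.7-fold lower number from compound 1 to compound 4 (0.22 log units; within the scatter), so in this series the change from a carbon chain to 2-sulfamoylethyl shows no separation on this read-out. With compound 3 held at a limit, the step from benzyl reads only as an at least 1.6-fold lower number from compound 3 to compound 4 (0.22 log units; that floor lies within the scatter), and a limit stands behind that floor: the limit of > 10 mg/kg in this assay, at which 1 of the 4 values shown sits.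

On these data alone, how far compound 3 lies from compound 4 stays open. So does whether a carboxylic acid, an amine or a longer chain at this place would also stay within the scatter of compound 4.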